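Imine aryl exchange carried onto a second core

The source may report more compounds than this note shows. Statements on the series, on what has been measured and on what is new or still open speak of the compounds shown alone.

Measured so far in a functional assay on MCF7 cells (Homo sapiens) for antiproliferative activity, read by MTT assay; a lower number here means a stronger inhibitor, a higher number a weaker inhibitor:
- compound 1 `NS(=O)(=O)c1ccc(Nc2ncc(/N=C/c3cccs3)c(NC3CCCC3)n2)cc1` gives 23000 nM
- compound 3 `CC(C)Nc1nc(Nc2ccc(N3CCN(C)CC3)cc2)ncc1/N=C/c1cccs1` gives 91100 nM
- compound 2 `NS(=O)(=O)c1ccc(Nc2ncc(/N=C/c3ccc(C(F)(F)F)cc3)c(NC3CCCC3)n2)cc1` reaches only a limit of the assay, > 100000 nM.

Compound 1 and compound 3 differ in more than one place; the difference between the two cores is not broken down here. Of the two numbers, compound 3 stands highest, and its gap to compound 1 lies beyond the scatter.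

On the core of compound 1 the change 4-(trifluoromethyl)phenyl in place of thiophen-2-yl on a carbon with a double bond to nitrogen gives an at least 4.3-fold higher number from compound 1 to compound 2 (0.63 log units; beyond the scatter). The true size of that step is hidden, since the result for compound 2 sits at the limit of > 100000 nM in this assay, at which 1 of the 3 values shown sits.

Compound 4 `CC(C)Nc1nc(Nc2ccc(N3CCN(C)CC3)cc2)ncc1/N=C/c1ccc(C(F)(F)F)cc1` is not yet measured. It carries the same change onto the core of compound 3: 4-(trifluoromethyl)phenyl in place of thiophen-2-yl on a carbon with a double bond to nitrogen. The two changes sit in the same place and are the same change.

Because compound 3 already gives 91100 nM, the earlier step points to a result for compound 4 beyond the reach of this assay. The step is expected to be at least as large as the earlier one, a 4.4-fold higher number from compound 3 to compound 4 (0.64 log units; beyond the scatter). For compound 4 the expected value is 400000 nM, most probably reported only as a limit. For compound 4 the expected band spans 120000 nM to 1500000 nM.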

Compound 4, half-maximal inhibitory concentration: > 100000 nM
Compound 4: a limit, no number (the forecaster's own chance of this, stated with the estimate: 80%); the middle value lies beyond the limit too.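

In this assay compound 4 gives > 100000 nM, which is a limit of the assay and not a number. Carried onto the core of compound 3, 4-(trifluoromethyl)phenyl in place of thiophen-2-yl gives an at least 1.0-fold higher number from compound 3 to compound 4 (0.04 log units; that floor lies within the scatter); this shows that no lower number appears with this change on either core, but it does not establish a rise on this core, as the floor of the step lies within the scatter. Whether the change has the same size on the two cores remains undecided, and no transfer of a measured step size can be claimed from these two pairs: the same change on two cores in this assay, an at least 4.3-fold higher number (0.63 log units; beyond the scatter) from compound 1 to compound 2 and an at least 1.0-fold higher number (0.04 log units; that floor lies within the scatter) from compound 3 to compound 4; the limit leaves it open whether they differ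

The compounds shown leave open how other aryl groups on the carbon with a double bond to nitrogen would read in this assay, for example a phenyl ring carrying a carboxylic acid, an amine or a nitrile in place of trifluoromethyl, and whether any of them would give a lower number than thiophen-2-yl. They also leave open which of the places that differ between the core of compound 1 and the core of compound 3 accounts for the gap between the two thiophen-2-yl compounds, since no pair shown changes one of those places alone.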